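The source may report more compounds than this note shows. Statements on the series, on what has been measured and on what is new or still open speak of the compounds shown alone.

Three compounds have been measured in a functional assay on HeLa cells (Homo sapiens) for antiproliferative activity, read by CCK-8 assay, with a stated time of 48 h; a higher number here means a weaker inhibitor, a lower number a stronger inhibitor:

Compound 1 `CC(C)CSc1n[nH]c(-n2[se]c3ccccc3c2=O)n1` gives 34900 nM.
Compound 2 `O=c1c2ccccc2[se]n1-c1nc(SCc2ccc(F)cc2)n[nH]1` gives > 50000 nM, which is a limit of the assay and not a number.
Compound 3 `O=c1c2ccccc2[se]n1-c1nc(SCc2ccccc2)n[nH]1` gives > 50000 nM, likewise a limit of the assay and not a number.

Compound 3 thus stands at the edge of what this assay can report: two of the three values sit at that edge (the limit of > 50000 nM in this assay, at which 2 of the 3 values shown sit), and only compound 1 gives a number. The step of an at least 1.4-fold higher number from compound 1 to compound 3 (0.15 log units; that floor lies within the scatter) shows that swapping the branched alkyl for an aromatic group did not sharpen inhibition, and the step that the two limits leave unreadable from compound 2 to compound 3 cannot be read because both ends are limits.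

Compound 4 `CCCCCSc1n[nH]c(-n2[se]c3ccccc3c2=O)n1` differs from compound 3 by butyl in place of phenyl on a saturated chain carbon bound to a sulfur. This returns the thioether substituent to a plain alkyl chain, closer in kind to compound 1 than to compound 3. Within the data shown here, the one step that bears on it, an at least 1.4-fold higher number from compound 1 to compound 3 (0.15 log units; that floor lies within the scatter), ran toward the limit when an aromatic group replaced the alkyl, so the reverse kind of change is expected to pull the value back toward the number seen for compound 1, though a modest step at most.

Compound 4 is therefore estimated at 35000 nM, within 15000 nM to 80000 nM, an expected step of an at least 1.4-fold lower number from compound 3 to compound 4 (0.15 log units; that floor lies within the scatter).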

Compound 4, half-maximal inhibitory concentration: 30300 nM
The estimate for compound 4 lay 1.2-fold (0.06 log units) above the measured number; measured number inside the range.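

Compound 4 gives this position a second plain alkyl group with a readable number in this assay, and swapping one alkyl group for the other gives a 1.2-fold lower number from compound 1 to compound 4 (0.06 log units; within the scatter), so the two alkyl compounds cannot be told apart. Against the aromatic groups, the change to butyl gives an at least 1.6-fold lower number from compound 3 to compound 4 (0.21 log units; that floor lies within the scatter) and an at least 1.6-fold lower number from compound 2 to compound 4 (0.21 log units; that floor lies within the scatter); each is only a floor, so these steps do not establish a real gain, although the true size could be larger. In the four compounds shown, the two with a readable number carry alkyl groups, while compound 2 and compound 3 each stay at a limit of the assay and not at a number: the limit of > 50000 nM in this assay, at which 2 of the 4 values shown sit.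

Among these compounds, no step that can be read here goes beyond the scatter, so it remains open whether an amine or a carboxylic acid at the end of the chain, or a much longer chain such as decyl, would clearly shift the number. From the compounds shown here alone, it also remains open how much of the level seen in these values comes from the shared core and how much from the group on the sulfur.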